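Aniline ring swap on a chalcone-thiazole series

The source may report more compounds than this note shows. Statements on the series, on what has been measured and on what is new or still open speak of the compounds shown alone.

Compound 1 `Cc1nc(Nc2cccc(Cl)c2)sc1C(=O)/C=C/c1ccccc1` is the reference. In a functional assay on NCI-H460 cells (Homo sapiens) for cytotoxicity, read by MTT assay (a lower number here means a stronger inhibitor, a higher number a weaker inhibitor), compound 1 gives > 25000 nM, which is a limit of the assay and not a number. Compound 2 `Cc1nc(Nc2cccc(Cl)c2)sc1C(=O)/C=C/c1ccc(Cl)cc1` gives > 25000 nM in this assay, again a limit. Compound 3 `COc1cccc(/C=C/C(=O)c2sc(Nc3cccc(Cl)c3)nc2C)c1` gives > 25000 nM in this assay, also a limit. All three values sit at the limit of > 25000 nM in this assay, at which 3 of the 3 values shown sit, so a step that the two limits leave unreadable from compound 1 to compound 2, a step that the two limits leave unreadable from compound 1 to compound 3 and a step that the two limits leave unreadable from compound 2 to compound 3 cannot be sized; the three measured steps vary only the phenyl attached to the double-bonded chain carbon.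

Compound 4 `Cc1ccc(Nc2nc(C)c(C(=O)/C=C/c3ccccc3)s2)cc1` differs from compound 1 by 4-methylphenyl in place of 3-chlorophenyl on a nitrogen on an aromatic ring. For the measured compounds named here, no measured step touches the nitrogen on the aromatic ring, so none bears directly on this change. Going by the values given here, the only guide is that every value shown sits at the limit of > 25000 nM in this assay, at which 3 of the 3 values shown sit, and nothing points to a gain in potency from altering either aryl ring. Compound 4 is therefore expected to remain at or near the limit, estimated at 35000 nM with a range of 8000 nM to 150000 nM. The step implied for compound 4 is estimated as a step that the limit leaves unreadable from compound 1 to compound 4, expected to lie within the scatter.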

Compound 4, half-maximal inhibitory concentration: > 25000 nM
Compound 4 ended at the assay's limit; the forecaster's own chance of this, stated with the estimate: 85%; the middle value does not contradict the limit.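

In this assay compound 4 gives > 25000 nM, a limit and not a number. For the compounds shown here, no step from compound 1 to compound 4 can be read, and the series stays flat: the limit of > 25000 nM in this assay, at which 4 of the 4 values shown sit. Going by these compounds, whether any change to either aryl ring on the shared core gives a measurable potency in this assay stays open.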